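Benzylic substituent swaps and tolerated concentration on kidney cells

The compounds below may be only part of what the source reports. "The series", "measured", "known", "first", "only" and "open" are said of these compounds alone.

Compound 1 `COc1ccc([C@H](C)N(Cc2ccc(C(C)(C)C)cc2)Cc2cc3cc(OC)ccc3[nH]c2=O)cc1` gives 4100 nM in a toxicity assay on MDCK cells (Canis lupus familiaris) for cytotoxicity, read by crystal violet staining, with a stated time of 48 h; a lower number here means that less compound is tolerated, a higher number that more compound is tolerated. Compound 2 `COc1ccc2[nH]c(=O)c(CN(Cc3ccc(C(C)(C)C)cc3)C(C)c3ccc(OC)c(Cl)c3)cc2c1` reaches only a limit in this assay, reported as > 10000 nM. The step of an at least 2.4-fold higher number from compound 1 to compound 2 (0.38 log units; beyond the scatter) is accordingly known only as a bound, set by the limit of > 10000 nM in this assay, at which 1 of the 2 values shown sits. Compound 3 `COc1ccc2[nH]c(=O)c(CN(Cc3ccc(C(C)(C)C)cc3)Cc3ccc(C(F)(F)F)c(Cl)c3)cc2c1` differs from compound 2 by 3-chloro-4-(trifluoromethyl)benzyl in place of 1-(3-chloro-4-methoxyphenyl)ethyl on an amine nitrogen. Within the data shown here, no measured step alters this position in the same way, so the bounded step from compound 1 to compound 2 is the only guide, and it cannot define a direction. Compound 3 is expected to remain near the limit, with an at least 1.1-fold lower number from compound 2 to compound 3 (0.04 log units; that floor lies within the scatter) expected to stay within the scatter. The estimate for compound 3 is 9000 nM, ranging from 3000 nM to 25000 nM.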

Compound 3, half-maximal cytotoxic concentration: > 10000 nM
Compound 3 ended at the assay's limit; the forecaster's own chance of this, stated with the estimate: 50%; middle value at least 1.1-fold (0.04 log units) from the limit.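

In this assay compound 3 gives > 10000 nM, which is a limit of the assay and not a number. On the amine nitrogen, 3-chloro-4-(trifluoromethyl)benzyl in place of 1-(4-methoxyphenyl)ethyl gives an at least 2.4-fold higher number from compound 1 to compound 3 (0.38 log units; beyond the scatter), so a second chloro-bearing group at this place now stands clear of the value of compound 1. The step between the two chloro-bearing compounds cannot be read: the limit of > 10000 nM in this assay, at which 2 of the 3 values shown sit.

Whether the chloro group alone accounts for these steps stays open. From the compounds shown here alone, how an amine or a carboxylic acid in place of the trifluoromethyl would read in this assay also stays open.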